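Notes on compound 3: pyridin-4-yl replacing 2,4-dichlorophenyl

The compounds below may be only part of what the source reports. "The series", "measured", "known", "first", "only" and "open" are said of these compounds alone.

Two compounds of the series have numbers in an ADME assay on the whole organism for cytotoxicity, with Artemia salina as the target, with a stated time of 24 h; a lower number here means that less compound is needed, a higher number that more compound is needed for the effect. Compound 1 `Cc1ccc(S(=O)(=O)NC(=O)Nc2ccccc2C(=O)/C=C/c2ccc(N(C)C)cc2)cc1` gives 38.1 ug/mL in this assay, and compound 2 `Cc1ccc(S(=O)(=O)NC(=O)Nc2ccccc2C(=O)/C=C/c2ccc(Cl)cc2Cl)cc1` gives 8.34 ug/mL. Among these two numbers compound 2 stands lowest, with compound 1 as its only neighbour. Among the compounds with values here, the single measured step in this assay runs a 4.6-fold lower number from compound 1 to compound 2 (0.66 log units; beyond the scatter), so an exchange of the aryl group at that chain carbon has so far moved the number by a modest amount.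

Compound 3 `Cc1ccc(S(=O)(=O)NC(=O)Nc2ccccc2C(=O)/C=C/c2ccncc2)cc1` differs from compound 2 in one place: pyridin-4-yl in place of 2,4-dichlorophenyl on a double-bonded chain carbon bound to a double-bonded chain carbon. Within the data shown here, no measured step bears directly on a pyridine at this place; the only step that touches the same position is a 4.6-fold lower number from compound 1 to compound 2 (0.66 log units; beyond the scatter), and it gives the scale to expect rather than the direction. Since compound 2 holds the lowest number of the two and the remaining exchange gave a higher one, compound 3 is expected to need more compound, with the step of a 3.0-fold higher number from compound 2 to compound 3 (0.48 log units; beyond the scatter) expected to fall beyond the scatter but not to exceed the step seen so far in size. The estimate for compound 3 in this assay is 25 ug/mL, with an expected range from 10 ug/mL to 60 ug/mL.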

Compound 3, concentration for half-maximal effect: 16.8 ug/mL
Estimate against measurement, compound 3: 1.5-fold (0.17 log units) above; low and high end bracket the measured number.
By their numbers in this assay, from the lowest: compounds 2 and 3 (each within the scatter of the next); then compound 1.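

In this assay the exchange at this place reads a 2.0-fold higher number from compound 2 to compound 3 (0.30 log units; within the scatter), so pyridin-4-yl and 2,4-dichlorophenyl are not separated on a double-bonded chain carbon bound to a double-bonded chain carbon, even though the entering ring carries a ring nitrogen and no chlorine. The other new step, a 2.3-fold lower number from compound 1 to compound 3 (0.36 log units; beyond the scatter), runs in the same direction as a 4.6-fold lower number from compound 1 to compound 2 (0.66 log units; beyond the scatter), and among the three aryl groups shown, 4-(dimethylamino)phenyl therefore stands apart from the other two, while an aromatic ring of carbon only and one with a hetero atom give numbers within the scatter of each other. Nothing measured is at hand to explain either the separation of compound 1 or the closeness of compound 2 and compound 3.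

Going by these compounds, whether a plain phenyl, or a morpholine or another amine on the phenyl ring, would fall with compound 2 and compound 3 or with compound 1 stays open, so the three numbers do not yet tell whether the dimethylamino group alone sets compound 1 apart. How far the rest of the shared core shapes these numbers also stays open, as the compounds shown differ only at this one place.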